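Halogenated versus dimethyl aryl on the pyrazole nitrogen

A few compounds are considered here, and "the series" means these few. Any claim that something is new, unique, unknown or untested is made for them only; others in the source may bear on it.

The series shares one core, an amide-linked pair with a five-membered aromatic ring carrying a methyl group and an aryl substituent on one ring nitrogen. Compound 1 `Cc1c(C(=O)Nc2ccc3ccccc3n2)cnn1-c1c(F)cccc1Br` carries a 2-bromo-6-fluorophenyl there and in a functional assay on SW480 cells (Homo sapiens) for inhibition (a lower number here means a stronger inhibitor of growth, a higher number a weaker inhibitor of growth), compound 1 gives 3900 nM. For the measured compounds named here, compound 2 `Cc1ccc(C)c(-n2ncc(C(=O)Nc3ccc4ccccc4n3)c2C)c1` carries a 2,5-dimethylphenyl instead, and in this assay compound 2 gives 24600 nM, the highest of the two numbers so far; the single step of a 6.3-fold higher number from compound 1 to compound 2 (0.80 log units; beyond the scatter) is the only comparison available.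

Compound 3 `Cc1c(C(=O)Nc2ccc3ccccc3n2)cnn1-c1cccc(Cl)c1F` differs from compound 2 in one place: 3-chloro-2-fluorophenyl in place of 2,5-dimethylphenyl on an aromatic nitrogen. This change returns the aryl to a halogenated pattern, which bears a resemblance to compound 1 without being the same substitution pattern. Going by the values given here, the one step that bears on it, a 6.3-fold higher number from compound 1 to compound 2 (0.80 log units; beyond the scatter), ran in the direction of a higher number when halogens were exchanged for methyls; the reverse exchange is therefore expected to bring the number back down, though not necessarily the full way, since the halogen positions differ.

For compound 3 in this assay the expected step is a 3.5-fold lower number from compound 2 to compound 3 (0.55 log units; beyond the scatter). Compound 3 is thus estimated at 7000 nM, with a range from 2500 nM to 20000 nM.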

Compound 3, concentration for 50% growth inhibition: 9000 nM
The estimate for compound 3 lay 1.3-fold (0.11 log units) below the measured number; low and high end bracket the measured number.
By their numbers in this assay, from the lowest: compound 1; then compound 3; then compound 2.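

In this assay, the exchange of 2,5-dimethylphenyl for 3-chloro-2-fluorophenyl on the aromatic nitrogen gives a 2.7-fold lower number from compound 2 to compound 3 (0.44 log units; beyond the scatter), so a second halogenated aryl also lies below the dimethyl aryl. The two halogenated aryl groups are not equivalent, however: the step is a 2.3-fold higher number from compound 1 to compound 3 (0.36 log units; beyond the scatter), which means that the presence of halogen alone does not fix the number at this position, and that step changes both the identity and the placement of the halogens at once, so it cannot assign the gap to either. No measurement among the data bears on why these aryl groups differ.

The three compounds give an order at this position but do not show how an unsubstituted phenyl or a methoxy-substituted phenyl would compare with these aryl groups. From the compounds shown here alone, it also remains open whether the same order would hold if the methyl group on the five-membered ring were replaced by an ethyl group.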